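Removing the 4-fluorophenyl group from compound 2

The source may report more compounds than this note shows. Statements on the series, on what has been measured and on what is new or still open speak of the compounds shown alone.

Values in a functional assay on A549 cells (Homo sapiens) for cytotoxicity, read by MTT assay, with a stated time of 48 h; on this read-out higher numbers stand for weaker inhibition and lower numbers for stronger inhibition:
- compound 1 `CN(C)CCCCCSC1=Nc2ccccc2C(CC(=O)NCc2ccccc2)N1c1ccc(-c2ccc(F)cc2)cc1` gives 17600 nM
- compound 2 `O=C(CC1c2ccccc2N=C(SCCCCCN2CCCC2)N1c1ccc(-c2ccc(F)cc2)cc1)NCc1ccccc1` gives 17800 nM
- compound 3 `CN(C)CCCCCSC1=Nc2ccccc2C(CC(=O)NCc2ccc(F)cc2)N1c1ccc(-c2ccc(F)cc2)cc1` gives 11300 nM

All three numbers lie within the scatter of one another, so compound 2 cannot be ranked against the other two. Compound 4 `O=C(CC1c2ccccc2N=C(SCCCCCN2CCCC2)N1c1ccccc1)NCc1ccccc1` has not yet been measured. Its structure differs from that of compound 2 as follows: hydrogen in place of 4-fluorophenyl on an aromatic carbon. In words, this is hydrogen in place of 4-fluorophenyl on an aromatic carbon.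

Two measured steps offer some guidance, though neither resembles this change. Pyrrolidin-1-yl in place of dimethylamino gave a 1.0-fold higher number from compound 1 to compound 2 (0.00 log units; within the scatter), and fluoro in place of hydrogen on an aromatic carbon gave a 1.6-fold lower number from compound 1 to compound 3 (0.19 log units; within the scatter). Both are small edits, and all three measured compounds carry the 4-fluorophenyl group, so no measurement shows what happens without it.

Starting from compound 2 at 17800 nM, losing a whole ring is a much larger edit than either step. A step beyond the scatter is therefore expected in this assay, probably towards a higher number, meaning weaker inhibition, but this direction is a judgement and not a result. The expected change is a 1.8-fold higher number from compound 2 to compound 4 (0.25 log units; within the scatter). For compound 4 the estimated value is 32000 nM, with an expected range from 14000 nM to 75000 nM.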

Compound 4, half-maximal inhibitory concentration: 98100 nM
The estimate for compound 4 lay 3.1-fold (0.49 log units) below the measured number; the whole stated range lies below it.
By their numbers in this assay, from the lowest: compounds 3, 1 and 2 (each within the scatter of the next); then compound 4.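

In this assay, among the compounds shown here, replacing the 4-fluorophenyl group with hydrogen gives a 5.5-fold higher number from compound 2 to compound 4 (0.74 log units; beyond the scatter), the only step in this set that lies beyond the scatter. For the compounds shown here, the two earlier edits, pyrrolidin-1-yl for dimethylamino with a 1.0-fold higher number from compound 1 to compound 2 (0.00 log units; within the scatter) and fluoro for hydrogen with a 1.6-fold lower number from compound 1 to compound 3 (0.19 log units; within the scatter), both stayed within it, so this is the first sign that a change in these molecules can clearly shift the number, and here the shift is towards weaker inhibition. Nothing shown here accounts for why this change has an effect of this size.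

The step removes a whole ring and its fluorine together, so a plain phenyl group at this place would help separate the two, and a small group such as methyl would test whether a full ring is needed at all. As far as these compounds go, the finding also rests on a single pair of compounds, so whether the same replacement gives a similar step when made on compound 1 or compound 3 remains open.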